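The source may hold more compounds than are shown below. What is called first, only, known or untested is meant among the compounds shown, and "the series" means these compounds.

Measured in a functional assay on HeLa cells (Homo sapiens) for antiproliferative activity, read by MTT assay, with a stated time of 48 h; a lower number here means a stronger inhibitor, a higher number a weaker inhibitor:

Compound 1 `COc1cc(CNC(=O)CCCCCCC(C)C)ccc1OC(=O)CCC(=O)Oc1ccc(-c2cc(=S)ss2)cc1`: 5530 nM
Compound 2 `COc1cc(CNC(=O)CCCC/C=C/C(C)C)ccc1OC(=O)CCC(=O)Oc1ccc(-c2cc(=S)ss2)cc1`: 4250 nM
Compound 3 `COc1cc(CNC(=O)CCCC/C=C/C(C)C)ccc1OCCCCOc1ccc(-c2cc(=S)ss2)cc1`: 47100 nM

Compound 2 and compound 1 share one core and differ by isopentyl in place of 3-methylbut-1-en-1-yl on a saturated chain carbon, four bonds along the chain from a carbonyl carbon; the step of a 1.3-fold higher number from compound 2 to compound 1 (0.11 log units; within the scatter). Compound 3 carries a different core; the difference between the core of compound 3 and the core of compound 2 is not broken down here, and the two values simply show compound 3 giving a much higher number in this assay than compound 2.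

Compound 4 `COc1cc(CNC(=O)CCCCCCC(C)C)ccc1OCCCCOc1ccc(-c2cc(=S)ss2)cc1` is not yet measured. It differs from compound 3 by isopentyl in place of 3-methylbut-1-en-1-yl on a saturated chain carbon, four bonds along the chain from a carbonyl carbon, the same change as that from compound 2 to compound 1. Because the earlier step of a 1.3-fold higher number from compound 2 to compound 1 (0.11 log units; within the scatter) stayed within the scatter, compound 4 is expected to sit close to compound 3 in this assay, with an expected step of a 1.2-fold higher number from compound 3 to compound 4 (0.07 log units; within the scatter). The estimate for compound 4 is 55000 nM, expected between 25000 nM and 120000 nM.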

Compound 4, half-maximal inhibitory concentration: 44700 nM
Compound 4: middle estimate off by 1.2-fold (0.09 log units), on the high side, and the stated range covers the measured number.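

In this assay, replacing 3-methylbut-1-en-1-yl with isopentyl gives a 1.1-fold lower number from compound 3 to compound 4 (0.02 log units; within the scatter), so removing this double bond leaves the number unmoved on the second core as well. The change therefore reads the same on both cores: the same change on two cores in this assay, a 1.3-fold higher number (0.11 log units; within the scatter) from compound 2 to compound 1 and a 1.1-fold lower number (0.02 log units; within the scatter) from compound 3 to compound 4, 1.4-fold (0.14 log units) apart, within the scatter of two such steps. Among these compounds, this shows only that a step too small to read carries over between these two cores; it does not show that a step of real size would carry over, nor does it speak for any other core or assay.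

Going by these compounds, whether a longer chain, or an amine or a carboxylic acid in place of isopentyl, would shift the number on either core remains open. Also open is which part of the difference between the cores accounts for the much higher numbers of compound 3 and compound 4.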